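The source may report more compounds than this note shows. Statements on the series, on what has been measured and on what is new or still open speak of the compounds shown alone.

In a functional assay on DU-145 cells (Homo sapiens) for inhibition, read by MTT assay, with a stated time of 48 h (a higher number here means a weaker inhibitor of growth, a lower number a stronger inhibitor of growth), compound 1, whose structure is `C#CCN(C)Cc1cccc(NC(=O)CCCCCCC(=O)NO)c1`, gives 420 nM. Compound 2, with the structure `C#CCN(C)Cc1cccc(NC(=O)CCCCCCCC(=O)NO)c1`, gives 3780 nM in this assay. The change between them is (hydroxycarbamoyl)methyl in place of hydroxycarbamoyl on a saturated chain carbon, six bonds along the chain from a carbonyl carbon, and it produced a 9.0-fold higher number from compound 1 to compound 2 (0.95 log units; beyond the scatter).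

Compound 3, with the structure `C#CCN(C)Cc1ccc(NC(=O)CCCC(=O)NO)cc1`, is built on a different core, and the difference between the two cores is not broken down here. In this assay compound 3 reaches only the limit > 10000 nM, so no number is known for it, only (the limit of > 10000 nM in this assay, at which 1 of the 3 values shown sits).

Compound 4, whose structure is `C#CCN(C)Cc1ccc(NC(=O)CCCCC(=O)NO)cc1`, has not yet been measured. It differs from compound 3 by (hydroxycarbamoyl)methyl in place of hydroxycarbamoyl on a saturated chain carbon, three bonds along the chain from a carbonyl carbon. For the measured compounds named here, this is the same kind of change as the one from compound 1 to compound 2, but the place is not the same: there the change sat on a saturated chain carbon six bonds along the chain from a carbonyl carbon, here it sits on a saturated chain carbon three bonds along the chain from a carbonyl carbon.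

For compound 4 the expected step is an at least 2.0-fold lower number from compound 3 to compound 4 (0.30 log units; that floor lies within the scatter), a lower number, because compound 3 sits at the limit > 10000 nM and a longer chain here is expected to give a measurable number. The estimate for compound 4 in this assay is 5000 nM, with an expected range from 1500 nM to 20000 nM.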

Compound 4, concentration for 50% growth inhibition: > 10000 nM
Compound 4: a limit, no number; the forecaster's own chance of this, stated with the estimate: 40%; at least 2.0-fold (0.30 log units) between middle value and limit.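

In this assay compound 4 gives > 10000 nM and that is a limit, not a number. Compound 3 stands at a limit too, so no step can be read from compound 3 to compound 4: the limit of > 10000 nM in this assay, at which 2 of the 4 values shown sit. Still open, on these data alone, is whether replacing hydroxycarbamoyl with (hydroxycarbamoyl)methyl changes growth inhibition at all on this core, and whether any chain on it gives a measurable number.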